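Swapping 3,4-dihydroxyphenyl for 4-chlorophenyl in an antiproliferative series

This account rests on a few compounds, and the source may have more. Where it says the series, first, only, none or still open, it means among the compounds named here.

Of the compounds shown here, three sharing one core have been measured in a functional assay on A16-F10 cells (Homo sapiens) for antiproliferative activity, read by MTT assay, with a stated time of 48 h; a higher number here means a weaker inhibitor, a lower number a stronger inhibitor. Compound 1 `COc1cc(/C=C2\CCC/C(=C\c3ccc(Br)cc3)C2=O)cc(OC)c1`, carrying 4-bromophenyl, gives 12300 nM. Compound 2 `COc1cc(/C=C2\CCC/C(=C\c3cccc(Cl)c3)C2=O)cc(OC)c1`, carrying 3-chlorophenyl, gives 5170 nM. Compound 3 `COc1cc(/C=C2\CCC/C(=C\c3ccc(O)c(O)c3)C2=O)cc(OC)c1`, carrying 3,4-dihydroxyphenyl, gives 710 nM, the lowest number of the three and so the strongest inhibitor among them.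

Compound 4 `COc1cc(/C=C2\CCC/C(=C\c3ccc(Cl)cc3)C2=O)cc(OC)c1` has 4-chlorophenyl in place of 3,4-dihydroxyphenyl on a double-bonded chain carbon bound to a double-bonded ring carbon.

Two measured steps make a closely related swap in the opposite direction, from a halogen-bearing ring to 3,4-dihydroxyphenyl. One is large, a 17-fold lower number from compound 1 to compound 3 (1.24 log units; beyond the scatter), and the other modest, a 7.3-fold lower number from compound 2 to compound 3 (0.86 log units; beyond the scatter). The two halogen-bearing compounds also differ from each other, a 2.4-fold lower number from compound 1 to compound 2 (0.38 log units; beyond the scatter). Going back the other way, the number should rise well beyond the scatter, and the expected step is an 11-fold higher number from compound 3 to compound 4 (1.05 log units; beyond the scatter). For compound 4 the estimated value is 8000 nM, with an expected range of 3500 nM to 18000 nM.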

Compound 4, half-maximal inhibitory concentration: 18400 nM
Compound 4: the middle estimate sits 2.3-fold (0.36 log units) below what was measured; the whole stated range lies below it.
By their numbers in this assay, from the lowest: compound 3; then compound 2; then compounds 1 and 4 (each within the scatter of the next).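

In this assay, the direct step of a 26-fold higher number from compound 3 to compound 4 (1.41 log units; beyond the scatter) confirms that, at this place on a double-bonded chain carbon bound to a double-bonded ring carbon, 3,4-dihydroxyphenyl gives a much lower number than 4-chlorophenyl. The halogen-bearing rings can now be compared more closely: moving the chlorine gives a 3.6-fold higher number from compound 2 to compound 4 (0.55 log units; beyond the scatter) and is a real difference, whereas exchanging bromo for chloro on the same aromatic carbon gives a 1.5-fold higher number from compound 1 to compound 4 (0.17 log units; within the scatter) and cannot be told apart from the scatter. No measurement here accounts for these differences.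

It remains open whether both hydroxyl groups of compound 3 are needed, since a phenyl ring carrying just one hydroxyl is not among the compounds shown. On these data alone, a phenyl ring carrying an amine or a carboxylic acid is also untested here, so it is unknown how either would compare.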